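This account rests on a few compounds, and the source may have more. Where it says the series, first, only, none or still open, it means among the compounds named here.

Measured so far in an ADME assay on Raji cells (Homo sapiens) for cytotoxicity, read by CellTiter-Glo and resazurin assay, with a stated time of 72 h; on this read-out higher numbers stand for an effect only at larger amounts of compound and lower numbers for an effect already at smaller amounts:
Compound 1 `CCOC(=O)CCCCCOc1cccc(CN(C(=O)c2ccc(-c3ccco3)cc2)C(C)C)c1` gives > 26000 nM, a limit of the assay.
Compound 2 `CCOC(=O)CCCCCOc1cccc(CN(C(=O)c2ccc(-c3cccc(-c4nnc(C)o4)c3)cc2)C(C)C)c1` gives > 26000 nM, also a limit.
Compound 3 `CCOC(=O)CCCCCOc1cccc(CN(C(=O)c2ccc(-c3cccc(OC)c3)cc2)C(C)C)c1` gives > 21000 nM, again a limit and not a number.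

Compound 3 thus stands at the limit of > 21000 nM in this assay, at which 1 of the 3 values shown sits, while the other two values shown sit at the limit of > 26000 nM in this assay, at which 2 of the 3 values shown sit. None of the three measured steps can be read: a step that the two limits leave unreadable from compound 1 to compound 2, a step that the two limits leave unreadable from compound 1 to compound 3 and a step that the two limits leave unreadable from compound 2 to compound 3 all lie between two limits, so no direction or size is available from them.

Compound 4 `CCOC(=O)CCCCCOc1cccc(CN(C(=O)c2ccc(-c3ccc4cc[nH]c4c3)cc2)C(C)C)c1` is the next entry, differing from compound 3 only in 1H-indol-6-yl in place of 3-methoxyphenyl on an aromatic carbon. Every measured step touching this series is unreadable, and all three values rest on limits, so there is no basis for expecting a step beyond the scatter in this assay; the expectation is simply that compound 4 again reaches only a limit. The estimated step that the limit leaves unreadable from compound 3 to compound 4 is accordingly taken as none beyond the scatter. Compound 4 is therefore expected to give about 26000 nM, within a range from 10000 nM to 60000 nM.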

Compound 4, half-maximal effective concentration: > 26000 nM
Compound 4: only a limit was reported; the forecaster's own chance of this, stated with the estimate: 80%; the middle value lies on the limit itself.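

In this assay compound 4 gives > 26000 nM, a limit and not a number. The steps to compound 4 from compound 1, compound 2 and compound 3 cannot be read. The compounds shown leave open whether exchanging these aromatic groups changes the half-maximal effective concentration at all.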